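From an aminophenyl sulfide to a naphthyl sulfide

The source may hold more compounds than are shown below. What is called first, only, known or untested is meant among the compounds shown, and "the series" means these compounds.

Measured compounds:
compound 1, `Nc1ccc(SCC(=O)Nc2ccc3nc(NC(=O)c4ccc(C(F)(F)F)cc4)sc3c2)cc1`: 1220 nM
compound 2, `O=C(CSc1cccc(O)c1)Nc1ccc2nc(NC(=O)c3cc(Cl)cc(Cl)c3)sc2c1`: 1530 nM
compound 3, `Cc1cc(C)cc(C(=O)Nc2nc3ccc(NC(=O)CSc4ccc(Cl)cc4)cc3s2)c1`: > 100000 nM

Three compounds sharing one core were examined in a functional assay on U2OS cells (Homo sapiens) for antiproliferative activity, read by MTT assay, with a stated time of 72 h; a lower number here means a stronger inhibitor, a higher number a weaker inhibitor. Compound 1 gives 1220 nM, the lowest of the two numbers shown. Compound 2 gives 1530 nM, which sits within the usual scatter of compound 1, so the two cannot be ranked. Compound 3 returns only a limit, > 100000 nM, and that limit is the one noted as the limit of > 100000 nM in this assay, at which 1 of the 3 values shown sits.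

Compound 4, `O=C(CSc1ccc2ccccc2c1)Nc1ccc2nc(NC(=O)c3ccc(C(F)(F)F)cc3)sc2c1`, differs from compound 1 in a single place: naphthalen-2-yl in place of 4-aminophenyl on a sulfur. Among the compounds with values here, no pair of measured compounds shows this particular exchange, so the step has to be judged from the structures alone. The expectation is a modest loss of potency, a step of a 2.9-fold higher number from compound 1 to compound 4 (0.46 log units; beyond the scatter), larger than the scatter but far from the limit at which compound 3 sits. For compound 4 the estimated value in this assay is 3500 nM, expected to fall between 900 nM and 20000 nM.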

Compound 4, half-maximal inhibitory concentration: 3940 nM
Compound 4: the middle estimate sits 1.1-fold (0.05 log units) below what was measured; the measured number falls inside the stated range.
By their numbers in this assay, from the lowest: compounds 1 and 2 (each within the scatter of the next); then compound 4. At a limit, above all of these: compound 3.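

In this assay, within the data shown here, the exchange of 4-aminophenyl for naphthalen-2-yl on the sulfur gives a 3.2-fold higher number from compound 1 to compound 4 (0.51 log units; beyond the scatter), so this position, which the earlier compounds did not probe in a single-place change, accepts the larger group at a modest cost. The group that enters has two six-membered aromatic rings where the one leaving had a single ring, and it has no hydrogen-bond donor or acceptor, yet compound 4 still returns a measured value rather than a limit. Nothing measured here gives a cause for this step.

Since ring count and the amino group change together, a plain phenyl on the sulfur would be needed to separate the two. On these data alone, whether a carboxylic acid on that ring, or a longer chain between the sulfur and the carbonyl, would keep the activity also remains open.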